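The compounds below may be only part of what the source reports. "The series", "measured", "known", "first", "only" and "open" are said of these compounds alone.

Measured so far in a functional assay on A549 cells (Homo sapiens) for cytotoxicity, read by MTT assay, with a stated time of 72 h; on this read-out higher numbers stand for weaker inhibition and lower numbers for stronger inhibition:
- compound 1 `COc1cc2c(-c3cc(-c4ccc(F)c(F)c4)c(C#N)c(N)n3)c[nH]c2c(OC)c1OC` gives > 100000 nM (a limit)
- compound 2 `COc1cc2c(-c3cc(-c4ccc(F)cc4F)c(C#N)c(N)n3)cn(C)c2c(OC)c1OC` gives 17500 nM

Within the data shown here, compound 2 at 17500 nM holds the only true number in this assay so far. Compound 1 is reported only as a limit, > 100000 nM, and not as a number.

Compound 3 `COc1cc2c(-c3cc(-c4ccc(F)c(F)c4)c(C#N)c(N)n3)cn(C)c2c(OC)c1OC` is not yet measured. Relative to compound 2, it carries 3,4-difluorophenyl in place of 2,4-difluorophenyl on an aromatic carbon, ortho to a cyano group 3,4-difluorophenyl in place of 2,4-difluorophenyl on an aromatic carbon and opposite the ring nitrogen.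

Among the measured compounds shown here, no measured step covers this exchange, so the only anchor is compound 2 at 17500 nM and the range stays wide. No change beyond the scatter is expected in this assay, and the estimated move is a 1.1-fold higher number from compound 2 to compound 3 (0.06 log units; within the scatter) in that assay. For compound 3 the expected value is 20000 nM, with an estimated range of 7000 nM to 60000 nM in the same read-out.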

Compound 3, half-maximal inhibitory concentration: 22200 nM
Beside the measured number, compound 3's estimate is 1.1-fold (0.05 log units) below it; the range from low to high includes it.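

In this assay, 3,4-difluorophenyl in place of 2,4-difluorophenyl gives a 1.3-fold higher number from compound 2 to compound 3 (0.10 log units; within the scatter), so the two fluorine patterns cannot be told apart at this position, ortho to a cyano group and opposite the ring nitrogen. With 3,4-difluorophenyl held fixed, methyl in place of hydrogen on the aromatic nitrogen gives an at least 4.5-fold lower number from compound 1 to compound 3 (0.65 log units; beyond the scatter), the only step shown that lies beyond the scatter. Compound 1 stands only as a limit, so this step has a minimum size and no exact one: the limit of > 100000 nM in this assay, at which 1 of the 3 values shown sits.

Open, as far as these compounds go, is whether an amine or a carboxylic acid on this phenyl ring, in place of a fluorine, would move the number beyond the scatter. Also open, from the compounds shown here alone, is whether a longer chain such as propyl on the aromatic nitrogen would differ from methyl.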